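The source may hold more compounds than are shown below. What is called first, only, known or untested is meant among the compounds shown, and "the series" means these compounds.

The series rests on a shared core carrying a methylsulfanyl or methylsulfonyl group and a fluoro group. Compound 2 `CSc1cc(F)ccc1NCC1=NCCN1` and compound 1 `CS(=O)(=O)c1cc(F)ccc1NCC1=NCCN1` were examined in an assay for binding affinity to Alpha-1B adrenergic receptor (Homo sapiens), read by radioligand binding; a lower number here means a stronger inhibitor, a higher number a weaker inhibitor. Compound 2 gives 15.1 nM, while compound 1 gives 513 nM. The change between them is methylsulfonyl in place of methylsulfanyl on an aromatic carbon, and the step of a 34-fold higher number from compound 2 to compound 1 (1.53 log units; beyond the scatter) is large.

Compound 3 `CSc1c(F)cccc1NCC1=NCCN1` has the same atoms as compound 2 but joined differently; the difference between the two cores is not broken down here. In this assay compound 3 gives 240 nM, which stands second highest of the three numbers.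

Compound 4 `CS(=O)(=O)c1c(F)cccc1NCC1=NCCN1` is not yet measured. It differs from compound 3 by methylsulfonyl in place of methylsulfanyl on an aromatic carbon. Among the compounds with values here, this is the same kind of change as the one from compound 2 to compound 1, but the place is not identical: in compound 4 the methylsulfonyl sits ortho to a fluoro group, whereas in compound 1 it sits meta to a fluoro group. Within the data shown here, with only one earlier example, the expectation is that the step will again be large, although its size could differ.

For compound 4 the expected step is a 21-fold higher number from compound 3 to compound 4 (1.32 log units; beyond the scatter), resting on the step seen with compound 1 at a 34-fold higher number from compound 2 to compound 1 (1.53 log units; beyond the scatter). Compound 4 is therefore estimated at 5000 nM, with a likely range from 1500 nM to 20000 nM.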

Compound 4, inhibition constant: 2290 nM
For compound 4 the middle estimate is 2.2-fold (0.34 log units) above the measured one; the measured number falls inside the stated range.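

In this assay, methylsulfonyl in place of methylsulfanyl on an aromatic carbon again gives a weaker inhibitor, the new step being a 9.5-fold higher number from compound 3 to compound 4 (0.98 log units; beyond the scatter), so the direction of the change carries over from the core of compound 2 to the core of compound 3. The size of the step does not carry over unchanged, and the step is modest on the core of compound 3 where it was large on the core of compound 2: the same change on two cores in this assay, a 34-fold higher number (1.53 log units; beyond the scatter) from compound 2 to compound 1 and a 9.5-fold higher number (0.98 log units; beyond the scatter) from compound 3 to compound 4, 3.6-fold (0.55 log units) apart, beyond the scatter of two such steps These two pairs show that the direction held on both cores, but they do not show what sets the size of the step, nor how large it would be on any further core.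

The compounds shown hold only methylsulfanyl and methylsulfonyl at this place, so it remains open how a methylsulfinyl group, an ethylsulfonyl group or a sulfonamide would stand on either core. From the compounds shown here alone, it is also open whether the difference between the two steps would persist if the fluoro group gave way to a chloro group or a methoxy group.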